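The source may hold more compounds than are shown below. What is called first, only, known or untested is meant among the compounds shown, and "the series" means these compounds.

Working notes on the series of acetophenone-type ethers carrying a phenolic hydroxyl and a long oxygen-linked chain. Compound 1 `CC(=O)c1ccc(OCCCCC#N)cc1O` gives 0% in an assay on isolated protein for binding affinity to leukotriene B4 receptor 1 (Homo sapiens), tested at 1 uM; a higher number here means more inhibition at the concentration tested (going by the name of the read-out), a lower number less inhibition. Compound 2 `C=CCc1cc(C(C)=O)c(O)cc1OCCCCCCCCCCC#N` gives 14% in this assay. Compound 3 `CCc1cc(C(C)=O)c(O)cc1OCCCCCCC(C)(C)C#N` gives 30% in this assay, the highest of the three numbers: its gap to compound 2 and its gap to compound 1 both lie beyond the scatter. Compound 4 `CCc1cc(C(C)=O)c(O)cc1OCCCCCC[S+](C)[O-]` is not yet measured. Compared with compound 3 the difference is a group of 3 heavy atoms (1 carbon, 1 oxygen, 1 sulfur; no ring) in place of a group of 5 heavy atoms (4 carbon, 1 nitrogen; no ring), on a saturated chain carbon, six bonds along the chain from an oxygen on an aromatic ring. Among the measured compounds shown here, no measured pair shows this change, so its size is open; a modest downward step, at about the edge of the scatter, is expected for a number 10 percentage points lower from compound 3 to compound 4 (within the scatter). For compound 4 the estimate in this assay is 20%, between 2% and 42%.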

Compound 4, a percentage reported as inhibition, at one concentration (the size of the read-out at that concentration, not a potency): 50%
Estimate against measurement, compound 4: 30 percentage points below; the whole stated range lies below it.
By their numbers in this assay, from the lowest: compound 1; then compound 2; then compound 3; then compound 4.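

At this saturated chain carbon, six bonds along the chain from an oxygen on an aromatic ring, replacing 1-cyano-1-methylethyl gives a number 20 percentage points higher from compound 3 to compound 4 (beyond the scatter) in this assay. This first one-place comparison in the series shows that the chain end affects the read-out and that a nitrile is not required for inhibition at this level. Nothing available explains the rise. Going by these compounds, whether an amine or a carboxylic acid at this place would match the sulfur-containing group remains open. So does whether the gain would persist with a longer chain.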